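The source may hold more compounds than are shown below. What is called first, only, known or untested is meant among the compounds shown, and "the series" means these compounds.

Values in an ADME assay on L6 cells (Rattus norvegicus) for cytotoxicity, read by resazurin assay, with a stated time of 72 h; on this read-out lower numbers stand for stronger inhibition and higher numbers for weaker inhibition:
Compound 1 `O=C(NC(=O)c1ccccc1O)c1ccc(-c2ccccc2)cc1`: > 100 ug/mL (a limit of the assay)
Compound 2 `O=C(NC(=O)c1ccccc1O)c1ccc(F)cc1`: 38 ug/mL

Going by the values given here, compound 2 gives 38 ug/mL, the only true number so far. Compound 1 stands at > 100 ug/mL, and this value is a limit of the assay. The next compound to be measured is compound 3 `CS(=O)(=O)c1ccc(C(=O)NC(=O)c2ccccc2O)cc1`, which carries methylsulfonyl in place of fluoro on an aromatic carbon, para to a large group: methylsulfonyl in place of fluoro on an aromatic carbon.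

Among the compounds with values here, only one measured step bears on this change: an at least 2.6-fold lower number from compound 1 to compound 2 (0.42 log units; beyond the scatter), with fluoro in place of phenyl on an aromatic carbon. That step has one open end and involves a different group, so it suggests a direction more than a size. Compound 2, the fluoro member, holds the lower number at 38 ug/mL, so losing its fluoro for a larger group is expected to move the number upward in this assay. The expected change is modest and uncertain, a 1.4-fold higher number from compound 2 to compound 3 (0.16 log units; within the scatter). For compound 3 the estimated value is 55 ug/mL, with an expected range from 20 ug/mL to 100 ug/mL.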

Compound 3, half-maximal inhibitory concentration: > 100 ug/mL
Compound 3: a limit, no number (the forecaster's own chance of this, stated with the estimate: 25%); middle value at least 1.8-fold (0.25 log units) away from the limit.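

Going by these compounds alone, the result shows that in this assay, the phenyl of compound 1 is not the only group at this place, on an aromatic carbon para to a large group, that gives a weaker read-out than fluoro: methylsulfonyl in place of fluoro gives an at least 2.6-fold higher number from compound 2 to compound 3 (0.42 log units; beyond the scatter). Within the data shown here, until now, the only step at this place had involved phenyl, and it was open whether a non-aromatic, sulfur-bearing group would keep the number near that of compound 2. Of the three groups shown at this place, only fluoro gives a true number, and the step between compound 1 and compound 3 cannot be read, as the values of both are limits: the limit of > 100 ug/mL in this assay, at which 2 of the 3 values shown sit.

Going by these compounds, how far the number of compound 3 lies past its limit stays unknown, so methylsulfonyl and phenyl cannot be ranked against each other. Also open, on these data alone, is where an unsubstituted ring carbon, a chlorine, an amine or a carboxylic acid at this same place would fall relative to compound 2 in this assay, and whether any group here gives a lower number than fluoro.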